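A few compounds are considered here, and "the series" means these few. Any claim that something is new, unique, unknown or untested is made for them only; others in the source may bear on it.

Compound 1, `Cc1ccc2oc(=O)n(Cc3n[nH]c(=S)n3C)c2c1`, gives 11.8%.
Compound 2, `Cc1ccc2oc(=O)n(CC(=O)NN)c2c1`, gives 70.5%.
Compound 3, `CCNc1nnc(Cn2c(=O)oc3ccc(C)cc32)s1`, gives 33.8%.

In a functional assay on the whole organism for inhibition, with Mus musculus as the target, read by paw edema, with a stated time of 180 min, at a dose of 100 mg/kg by the oral route (a higher number here means a stronger effect of the compound at the dose given, a lower number a weaker effect), compound 2 stands highest of the three measured compounds. Compound 3 is the nearest to it, with a value lower by a gap beyond the scatter, and compound 1 lies furthest, also beyond the scatter. All three share the same core and differ only in the side chain on it.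

The unmeasured compound 4, `CCNC(=S)NNC(=O)Cn1c(=O)oc2ccc(C)cc21`, differs from compound 2 by a group of 5 heavy atoms (3 carbon, 1 nitrogen, 1 sulfur; no ring) in place of a hydrogen atom, on an amine nitrogen. The acylhydrazine part of compound 2 is kept, and only the terminal hydrogen is replaced.

Within the data shown here, no step between two measured compounds is available, so the expected size of the step in this assay rests on the spread of the three values: the two other side chains, in compound 1 and compound 3, sit well below compound 2. A moderate drop is therefore expected, beyond the scatter but not to the level of compound 1. Compound 4 is estimated at 50%, within 30% to 68%, which means an expected step of a number 20.5 percentage points lower from compound 2 to compound 4 (beyond the scatter).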

Compound 4, a percentage reported as inhibition, in the whole organism at one dose (the size of the read-out at that dose, not a potency): 36.3%
The estimate for compound 4 lay 13.7 percentage points above the measured number; measured number inside the range.
By their numbers in this assay, from the lowest: compound 1; then compounds 3 and 4 (each within the scatter of the next); then compound 2.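

In this assay, among these compounds, the change on the amine nitrogen gives a number 34.2 percentage points lower from compound 2 to compound 4 (beyond the scatter), the first reading of a change in one place. The earlier side chains differed from that of compound 2 as a whole, whereas here the acylhydrazine part is kept and only its terminal hydrogen gives way to a group of 5 heavy atoms, so this position alone is enough to move the effect by a large step, and compound 4 still gives 36.3%. Nothing available explains the size of this step.

The compounds shown leave open whether the thiocarbonyl or the ethyl end of the entering group matters more, since both enter together. An acetyl or a methyl on the same amine nitrogen, or an ethyl urea in place of the ethyl thiourea, would separate these parts.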